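Two compounds at one limit, and a thiazole swap

The source may report more compounds than this note shows. Statements on the series, on what has been measured and on what is new or still open speak of the compounds shown alone.

Compound 1 `C[C@H](O)[C@@H](CCC1CCCCC1)n1cnc2c(N)ncnc21`: > 0.5 h
Compound 2 `COC(=O)c1cccc(CC[C@H]([C@H](C)O)n2cnc3c(N)ncnc32)c1`: > 0.5 h

In an ADME assay on microsomes from liver (Mus musculus) for metabolic stability, read by LC-MS, using NADPH, with stated times of 5 min and 30 min, at 37 degrees C (a lower number here means that the compound disappears faster, a higher number that the compound lasts longer), compound 2 gives > 0.5 h, which is a limit of the assay and not a number. Compound 1 gives > 0.5 h, also a limit. What the two compounds share here is the limit of > 0.5 h in this assay, at which 2 of the 2 values shown sit.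

Compound 3 `C[C@H](O)[C@@H](CCc1cccc(-c2nccs2)c1)n1cnc2c(N)ncnc21` has 1,3-thiazol-2-yl in place of methoxycarbonyl on an aromatic carbon. Going by the values given here, no measured pair of compounds shows what this swap does. In this assay, no step beyond the usual scatter is expected, and no direction can be favoured. The estimated step is a number no higher from compound 2 to compound 3 (the limit leaves the size open). The assay may well report only a limit again. For compound 3 the expected half-life is 0.5 h, with an estimated range from 0.25 h to 1 h.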

Compound 3, half-life: > 0.5 h
Compound 3: a limit, no number (the forecaster's own chance of this, stated with the estimate: 65%); the middle value lies on the limit itself.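

In this assay compound 3 gives > 0.5 h, a limit of the assay and not a number. Going by these compounds alone, compound 2 also sits at a limit, so no step between compound 2 and compound 3 can be read. As far as these compounds go, how long either compound truly lasts, and what 1,3-thiazol-2-yl in place of methoxycarbonyl changes, stays open.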